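Series notes: compound 4, methoxy in place of fluoro

The source may hold more compounds than are shown below. What is called first, only, known or untested is meant among the compounds shown, and "the series" means these compounds.

Measured so far in an assay on isolated protein (Cavia porcellus) with Sigma non-opioid intracellular receptor 1 (Homo sapiens) as the target, read by radioligand binding; a lower number here means a stronger inhibitor, a higher number a weaker inhibitor:
- compound 1, `O=c1cc(-c2ccccc2)oc2ccc(OCCCCCCN3CCC(O)CC3)cc12`, gives 121 nM
- compound 2, `O=c1cc(-c2cccnc2)oc2ccc(OCCCCCCN3CCC(O)CC3)cc12`, gives 210 nM
- compound 3, `O=c1cc(-c2ccc(F)cc2)oc2ccc(OCCCCCCN3CCC(O)CC3)cc12`, gives 132 nM

Compound 3 sits second highest of the three numbers, but neither gap is meaningful: its nearest neighbour is compound 1, its furthest compound 2, and both differences stay inside the scatter, as a 1.1-fold higher number from compound 1 to compound 3 (0.04 log units; within the scatter) and a 1.6-fold lower number from compound 2 to compound 3 (0.20 log units; within the scatter) show. The whole set, including a 1.7-fold higher number from compound 1 to compound 2 (0.24 log units; within the scatter), is flat within the usual noise.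

Compound 4, `COc1ccc(-c2cc(=O)c3cc(OCCCCCCN4CCC(O)CC4)ccc3o2)cc1`, differs from compound 3 by methoxy in place of fluoro on an aromatic carbon.

Among the compounds with values here, the steps that bear on this change are the two that touch the same aromatic ring: a 1.1-fold higher number from compound 1 to compound 3 (0.04 log units; within the scatter) and a 1.6-fold lower number from compound 2 to compound 3 (0.20 log units; within the scatter). Both are within the scatter, so the data give no sign that exchanges on this ring move this assay by more than the noise. Within the data shown here, no measured pair covers a methoxy group itself, which leaves the direction open.

For compound 4 the estimate is therefore a number close to compound 3, 130 nM, with a range from 60 nM to 280 nM; the expected step of a 1.0-fold lower number from compound 3 to compound 4 (0.01 log units; within the scatter) is within the scatter.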

Compound 4, half-maximal inhibitory concentration: 332 nM
Compound 4: the middle estimate sits 2.6-fold (0.41 log units) below what was measured, and the stated range ends below it.
By their numbers in this assay, from the lowest: compounds 1, 3, 2 and 4 (each within the scatter of the next, the first and the last beyond it).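

In this assay, within the data shown here, methoxy is the first exchange on this ring to give a step beyond the scatter, seen in a 2.5-fold higher number from compound 3 to compound 4 (0.40 log units; beyond the scatter) and in a 2.7-fold higher number from compound 1 to compound 4 (0.44 log units; beyond the scatter) as well, both modest in size. The picture is not uniform, since a 1.6-fold higher number from compound 2 to compound 4 (0.20 log units; within the scatter) leaves compound 4 and compound 2 inseparable, so this aromatic carbon, para to a large group, is sensitive to the 4-fluorophenyl to 4-methoxyphenyl change and to the change from phenyl, but not to the change from pyridin-3-yl. No measurement at hand accounts for this step.

The compounds shown do not tell whether the higher number goes with the oxygen of methoxy or with its extra heavy atom, and a methyl, hydroxy, chloro or ethoxy group at the same place would be needed to separate those readings. From the compounds shown here alone, it also stays open whether methoxy would give a step of similar size on a shorter chain, or with the same group moved to another carbon of this ring.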